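Swapping the Aryl Group: An Estimate for Compound 4

The compounds below may be only part of what the source reports. "The series", "measured", "known", "first", "only" and "open" are said of these compounds alone.

Compound 1, `Cc1nnc(COc2cnn(C(C)(C)C)c(=O)c2Cl)o1`: in a functional assay on the whole organism for inhibition, with Mythimna separata as the target, with a stated time of 5 days (a lower number here means that less compound is needed, a higher number that more compound is needed for the effect), compound 1 reaches only the limit of > 299000 nM.
Compound 2, `CC(C)(C)n1ncc(OCc2nnc(-c3ccc(Cl)cc3)o2)c(Cl)c1=O`: compound 2 gives 1900 nM.
Compound 3, `CC(C)(C)n1ncc(OCc2nnc(-c3ccc(C(F)(F)F)cc3)o2)c(Cl)c1=O`: compound 3 gives 33800 nM.

Of the two numbers measured in this assay, compound 2 holds the lowest; its nearest neighbour is compound 3, which sits a large step away, and the third value, that of compound 1, is a limit and not a number. Two measured steps frame the group on the five-membered ring. The first is an at least 150-fold lower number from compound 1 to compound 2 (2.19 log units; beyond the scatter), a large gain. The second is an 18-fold higher number from compound 2 to compound 3 (1.25 log units; beyond the scatter), a large loss.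

Compound 4, `CC(C)(C)n1ncc(OCc2nnc(-c3ccccc3F)o2)c(Cl)c1=O`, has not yet been measured in this assay. It differs from compound 2 in one place: 2-fluorophenyl in place of 4-chlorophenyl on an aromatic carbon. Both measured steps touch the same position, and both were large, so the aromatic group at this place matters greatly. The step to compound 3 shows that exchanging one substituent on that ring already costs much. Compound 4 is therefore expected to give a higher number than compound 2, a loss estimated as a 5.3-fold higher number from compound 2 to compound 4 (0.72 log units; beyond the scatter). For compound 4 the estimated value in this assay is 10000 nM, with a range from 2500 nM to 60000 nM.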

Compound 4, half-maximal effective concentration: 16800 nM
Beside the measured number, compound 4's estimate is 1.7-fold (0.23 log units) below it; measured number inside the range.
By their numbers in this assay, from the lowest: compound 2; then compounds 4 and 3 (each within the scatter of the next). At a limit, above all of these: compound 1.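

Compound 4 shows that the gain over methyl at this carbon does not belong to 4-chlorophenyl alone, with an at least 17-fold lower number from compound 1 to compound 4 (1.25 log units; beyond the scatter). Even so, replacing 4-chlorophenyl costs again, with an 8.8-fold higher number from compound 2 to compound 4 (0.95 log units; beyond the scatter), so compound 2 remains apart from both other aryl compounds, while compound 3 at 33800 nM and compound 4 at 16800 nM lie within the scatter of each other. The size of the gain over methyl remains a bound, as compound 1 gives a limit and not a number: the limit of > 299000 nM in this assay, at which 1 of the 4 values shown sits.

As far as these compounds go, two things change at once between compound 2 and compound 4, the halogen and its place on the phenyl ring, and this single step cannot separate them, so the readings of 4-fluorophenyl, 2-chlorophenyl and unsubstituted phenyl in this assay remain open. Also open, from the compounds shown here alone, is how an aryl group carrying an amine or a carboxylic acid, or a longer chain in place of the aryl group, would read at this carbon of the five-membered ring.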